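A few compounds are considered here, and "the series" means these few. Any claim that something is new, unique, unknown or untested is made for them only; others in the source may bear on it.

The measured compounds are:
compound 1, `CCCc1cc(N)c2cc(NC(=O)/C=C/c3ccc(CC)cc3)ccc2n1`, with 1.4 nM in an assay on isolated protein for displacement of a labelled ligand from melanin-concentrating hormone receptor 1 (Homo sapiens); a higher number here means a weaker inhibitor, a lower number a stronger inhibitor;
compound 2, `CCCc1cc(N)c2cc(NC(=O)/C=C/c3ccc(C(C)C)cc3)ccc2n1`, with 2.9 nM;
compound 3, `Cc1cc(N)c2cc(NC(=O)/C=C/c3ccc(C(F)(F)F)cc3)ccc2n1`, with 8 nM.

Compounds 1 and 2 share one core and differ in a single place: methyl in place of hydrogen on a saturated chain carbon bound to an aromatic carbon and a saturated chain carbon. That change gave a 2.1-fold higher number from compound 1 to compound 2 (0.32 log units; beyond the scatter). Compound 3 rests on a different core; how its core differs from that of compound 1 is not broken down here. Among the three compounds, compound 3 gives the highest number, and its nearest neighbour is compound 2.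

Compound 4, `CCc1cc(N)c2cc(NC(=O)/C=C/c3ccc(C(F)(F)F)cc3)ccc2n1`, has not yet been measured. It differs from compound 3 by the same kind of change, (methyl in place of hydrogen on a saturated chain carbon bound to an aromatic carbon), though the place is not quite the same: in compound 4 it is a saturated chain carbon bound to an aromatic carbon only, whereas in compound 2 that carbon was bound to an aromatic carbon and a saturated chain carbon as well. One measured example of this kind of change is thin ground for a forecast, and it was a modest step. Beyond that, the whole range seen so far is narrow: compound 1 gave 1.4 nM and compound 2 gave 2.9 nM. The step is therefore expected to be small, a 1.3-fold lower number from compound 3 to compound 4 (0.12 log units; within the scatter). Compound 4 in this assay is estimated at 6 nM, expected to fall between 2.5 nM and 15 nM.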

Compound 4, half-maximal inhibitory concentration: 1.2 nM
Estimate against measurement, compound 4: 5.0-fold (0.70 log units) above; measured number below the stated range.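

In this assay, adding the methyl gave a 6.7-fold lower number from compound 3 to compound 4 (0.82 log units; beyond the scatter), whereas the earlier methyl step went the opposite way, and the two steps differ by more than repeat measurements would explain: the same change on two cores in this assay, a 2.1-fold higher number (0.32 log units; beyond the scatter) from compound 1 to compound 2 and a 6.7-fold lower number (0.82 log units; beyond the scatter) from compound 3 to compound 4, 14-fold (1.14 log units) apart, beyond the scatter of two such steps. This shows that, across these two pairs, the result of adding this methyl did not carry over from one core to the other in either direction or size, so the step from one pair would have been a poor guide to the other. It does not show why, since the pairs differ both in the rest of the molecule and in the carbon that takes the methyl, which is bound to an aromatic carbon only in compound 3 but also to a saturated chain carbon in compound 1, and one pair of each kind cannot separate these differences.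

The compounds shown leave open whether a longer chain, such as butyl, at the place changed in compound 4 would give a still lower number or reverse the step. They also leave open how a group of a different kind at that place, such as an amine or a carboxylic acid, would compare with the ethyl of compound 4.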